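This account rests on a few compounds, and the source may have more. Where it says the series, first, only, none or still open, it means among the compounds named here.

Compound 2 `COC(=O)c1cc(-c2cccc(NC(=O)c3ccc(/C=C/C(=O)c4ccc(Br)cc4)cc3)c2)on1` is the starting point. In an ADME assay on Vero cells (Chlorocebus sabaeus) for cytotoxicity, read by MTT assay, with a stated time of 72 h (a lower number here means that less compound is tolerated, a higher number that more compound is tolerated), compound 2 gives > 20 ug/mL, which is a limit of the assay rather than a measured number. Compound 1 `COC(=O)c1cc(-c2cccc(NC(=O)c3ccc(/C=C/C(=O)c4ccccc4Br)cc3)c2)on1` carries 2-bromophenyl on the carbonyl carbon where compound 2 carries 4-bromophenyl. In this assay compound 1 gives > 40 ug/mL, again only a limit. The step that the two limits leave unreadable from compound 1 to compound 2 therefore cannot be read in size or direction. Compound 3 `CCCOc1ccc(C(=O)/C=C/c2ccc(C(=O)O)cc2)cc1` is built around a different core. In this assay compound 3 gives < 10 ug/mL, also a limit. Going by the values given here, two of the three known values thus sit at upper limits the limit of > 20 ug/mL in this assay, at which 1 of the 3 values shown sits (the limit of > 40 ug/mL in this assay, at which 1 of the 3 values shown sits), and one sits at a lower limit (the limit of < 10 ug/mL in this assay, at which 1 of the 3 values shown sits), so no step in this set has a readable size.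

Compound 4 `COC(=O)c1cc(-c2cccc(NC(=O)c3ccc(/C=C/C(=O)c4cccc(OC)c4)cc3)c2)on1` is the next member. Relative to compound 2 the change is 3-methoxyphenyl in place of 4-bromophenyl on a carbonyl carbon. Among the compounds with values here, no measured step in this set follows this exchange, and the one step that shares the same place is unreadable. The expected step that the limit leaves unreadable from compound 2 to compound 4 from compound 2 to compound 4 is therefore put at none beyond the scatter. Compound 4 is estimated at 30 ug/mL, with a range from 15 ug/mL to 60 ug/mL, and the assay may again report only a limit.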

Compound 4, half-maximal cytotoxic concentration: > 100 ug/mL
Compound 4 ended at the assay's limit (the forecaster's own chance of this, stated with the estimate: 65%); middle value at least 3.3-fold (0.52 log units) away from the limit.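

In this assay compound 4 gives > 100 ug/mL, again only a limit of the assay, so its steps from compound 1 and from compound 2 cannot be read in size or direction. The compounds shown leave open whether 2-bromophenyl, 4-bromophenyl and 3-methoxyphenyl on a carbonyl carbon differ at all in how much compound is tolerated, and by how much.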